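Aryl replacement at the carbonyl carbon of the shared core

The compounds below may be only part of what the source reports. "The series", "measured", "known", "first", "only" and "open" are said of these compounds alone.

Two compounds of this series carry numbers in a functional assay on NCI-H460 cells (Homo sapiens) for cytotoxicity, read by sulforhodamine B assay, with a stated time of 48 h, tested at 1 uM; on this read-out higher numbers stand for a weaker effect at the one concentration tested and lower numbers for a stronger effect. Compound 1 `COc1cc(-c2cc(/C=C/C(=O)c3ccc(Cl)c(Cl)c3)[nH]n2)cc(OC)c1OC` gives 93% in this assay. Compound 2 `COc1ccc(C(=O)/C=C/c2cc(-c3cc(OC)c(OC)c(OC)c3)n[nH]2)cc1OC` gives 70% in this assay, the lowest of the two numbers, with compound 1 its nearest neighbour. Within the data shown here, the single measured step is a number 23 percentage points lower from compound 1 to compound 2 (beyond the scatter), beyond the scatter and modest in size.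

Compound 3 `COc1cc(-c2cc(/C=C/C(=O)c3ccc(F)c(F)c3)[nH]n2)cc(OC)c1OC` is not yet measured. It differs from compound 2 in one place: 3,4-difluorophenyl in place of 3,4-dimethoxyphenyl on a carbonyl carbon. Among the measured compounds shown here, the only measured step touching this position is the one from compound 1 to compound 2, in which 3,4-dichlorophenyl gave way to 3,4-dimethoxyphenyl. In what is counted, 3,4-difluorophenyl resembles the 3,4-dichlorophenyl of compound 1 rather than the 3,4-dimethoxyphenyl of compound 2, so the earlier step is expected to be largely undone, giving a number higher than that of compound 2. On this basis compound 3 is estimated at 87%, within 70% to 100%, because compound 1 gave 93% with a related group at the same carbonyl carbon. The expected step is a number 17 percentage points higher from compound 2 to compound 3 (beyond the scatter).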

Compound 3, a percentage reported as activity, at one concentration (the size of the read-out at that concentration, not a potency): 103%
Estimate against measurement, compound 3: 16 percentage points below, and the stated range ends below it.
By their numbers in this assay, from the lowest: compound 2; then compounds 1 and 3 (each within the scatter of the next).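

In this assay, 3,4-difluorophenyl in place of 3,4-dimethoxyphenyl on a carbonyl carbon gives a number 33 percentage points higher from compound 2 to compound 3 (beyond the scatter). This shows that the gap between compound 2 and compound 1 is not confined to that one pair: a second halogen-bearing aryl group also stands apart from the 3,4-dimethoxyphenyl of compound 2. 3,4-difluorophenyl in place of 3,4-dichlorophenyl gives a number 10 percentage points higher from compound 1 to compound 3 (within the scatter) and so does not separate the two halogen-bearing aryl groups on this read-out, which leaves compound 2 as the only one of the three set apart by a step beyond the scatter. Nothing measured among these compounds accounts for the position of the 3,4-dimethoxyphenyl group.

Still open, as far as these compounds go, is whether both methoxy groups are needed for the lower number, and how an aryl group carrying a single methoxy group, an amine or a carboxylic acid would read at this carbonyl carbon. These numbers come from one concentration and give no potency, so the size of the steps cannot be carried over to a concentration-response measure.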